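The compounds below may be only part of what the source reports. "The series", "measured", "known", "first", "only" and "open" are said of these compounds alone.

Measured compounds:
compound 1 `Cc1cccc(/C(N)=N/NC(=S)N2CCCCC2)n1` gives 43%
compound 2 `Cc1cccc(/C(N)=N/NC(=S)N2CCCC2)n1` gives 40.1%

In a functional assay on MCF7 cells (Homo sapiens) for cytotoxicity, read by MTT assay, with a stated time of 72 h, tested at 30 uM (a lower number here means less inhibition of growth, a higher number more inhibition of growth at the concentration tested), compound 1 stands beside compound 2: the step of a number 2.9 percentage points lower from compound 1 to compound 2 (within the scatter) lies within the scatter, so the two are indistinguishable on these numbers. Compound 3 `N/C(=N\NC(=S)N1CCCCC1)c1ccccn1` differs from compound 1 in one place: hydrogen in place of methyl on an aromatic carbon. Among the compounds with values here, the only measured step, a number 2.9 percentage points lower from compound 1 to compound 2 (within the scatter), concerns the group on the thiocarbonyl carbon and not the aromatic ring, so it bears only loosely on this change, and no measured step removes a methyl from the ring. The expected step is a number 1 percentage points lower from compound 1 to compound 3 (within the scatter), nothing beyond the scatter, with a wide range for want of a direct precedent. Compound 3 is expected to give 42% (range 27% to 57%).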

Compound 3, percent growth inhibition at one concentration: 69.3%
Estimate against measurement, compound 3: 27.3 percentage points below, outside the stated range (above it).
By their numbers in this assay, from the lowest: compounds 2 and 1 (each within the scatter of the next); then compound 3.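

In this assay, the aromatic carbon next to the ring nitrogen proves sensitive: hydrogen in place of methyl gives a number 26.3 percentage points higher from compound 1 to compound 3 (beyond the scatter). This is the first change shown that moves growth inhibition beyond the scatter, whereas the earlier step at the thiocarbonyl carbon did not. Nothing available explains the gain.

The compounds shown leave open whether a methoxy or an amine at this carbon would read like compound 1 or like compound 3. Also open, from the compounds shown here alone, is whether pyrrolidin-1-yl in place of piperidin-1-yl stays within the scatter when this carbon carries hydrogen.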